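From compound 3 to compound 4: limits only

The source may report more compounds than this note shows. Statements on the series, on what has been measured and on what is new or still open speak of the compounds shown alone.

Three compounds share one core and differ in the group on a triple-bonded carbon: compound 1 (`O=[N+]([O-])c1c(CS(=O)(=O)c2ccccc2)nc2c(C#Cc3ccc(F)cc3)cc(Cl)cn12`), compound 2 (`O=[N+]([O-])c1c(CS(=O)(=O)c2ccccc2)nc2c(C#Cc3ccccc3F)cc(Cl)cn12`) and compound 3 (`O=[N+]([O-])c1c(CS(=O)(=O)c2ccccc2)nc2c(C#Cc3ccc(CO)cc3)cc(Cl)cn12`). In an ADME assay on HepG2 cells (Homo sapiens) for cytotoxicity, read by MTT assay, with a stated time of 72 h (on this read-out higher numbers stand for lower toxicity in this test and lower numbers for higher toxicity in this test), compound 1 gives > 3900 nM as a limit and not a number. Compound 2 gives > 3900 nM as a limit too. Compound 3 gives > 15600 nM as a limit as well, so it has no measured number, and neither of the other two offers one to set against it.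

Compound 4 (`CCC(O)CC#Cc1cc(Cl)cn2c([N+](=O)[O-])c(CS(=O)(=O)c3ccccc3)nc12`) carries 2-hydroxybutyl in place of 4-(hydroxymethyl)phenyl on a triple-bonded carbon. The measured steps at this carbon are a step that the two limits leave unreadable from compound 1 to compound 3 and a step that the two limits leave unreadable from compound 2 to compound 3 and also a step that the two limits leave unreadable from compound 1 to compound 2 in the same series. None of them has a readable size or direction, and none has a chain without a ring entering at this carbon. On that footing, no step beyond the scatter is expected in this assay for this change. The estimate gives a step that the limit leaves unreadable from compound 3 to compound 4 as the expected step. The expected value for compound 4 is 16000 nM within a range from 6000 nM to 40000 nM. A limit rather than a number may well be the outcome for compound 4.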

Compound 4, half-maximal cytotoxic concentration: > 62500 nM
Compound 4: only a limit was reported; the forecaster's own chance of this, stated with the estimate: 70%; at least 3.9-fold (0.59 log units) between middle value and limit.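

In this assay compound 4 gives > 62500 nM, a limit and not a number. Among these compounds, compound 1, compound 2 and compound 3 also carry only limits, so no step to compound 4 can be read. Whether any group on the triple-bonded carbon shifts the result in this assay stays open, with no measured number among these four compounds.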